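The source may report more compounds than this note shows. Statements on the series, on what has been measured and on what is new or still open speak of the compounds shown alone.

In a functional assay on COLO 205 cells (Homo sapiens) for inhibition, read by sulforhodamine B assay, with a stated time of 48 h, tested at 50 uM (a higher number here means more inhibition of growth at the concentration tested, a lower number less inhibition of growth), compound 2 `COc1cccc(/C=C/C(=O)/C=C/c2ccc(OCc3cn(CCCCCOc4cc(=O)oc5ccccc45)nn3)c(OC)c2)c1` gives 34%. Within the data shown here, compound 1 `COc1cc(/C=C/C(=O)/C=C/c2cccc3ccccc23)ccc1OCc1cn(CCCCCOc2cc(=O)oc3ccccc23)nn1` gives 40%, within the scatter of that number, and the two together form the low end of the numbers so far. Compound 3 `COc1cc(/C=C/C(=O)/C=C/c2cc(OC)c(OC)c(OC)c2)ccc1OCc1cn(CCOc2cc(=O)oc3ccccc23)nn1` gives 86%, beyond the scatter above both, but it differs from compound 2 in more than one place and does not measure the change considered here.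

The next case is compound 4 `COc1ccccc1/C=C/C(=O)/C=C/c1ccc(OCc2cn(CCCCCOc3cc(=O)oc4ccccc34)nn2)c(OC)c1`, reached by 2-methoxyphenyl in place of 3-methoxyphenyl on a double-bonded chain carbon bound to a double-bonded chain carbon. Among the measured compounds shown here, the only measured step at this place is a number 6 percentage points lower from compound 1 to compound 2 (within the scatter), a replacement of naphthalen-1-yl by 3-methoxyphenyl that stays within the scatter. For the measured compounds named here, no measured pair tests 2-methoxyphenyl itself. Going by the values given here, with only that small step as a guide, no shift beyond the scatter is expected, and the estimated step is a number 2 percentage points higher from compound 2 to compound 4 (within the scatter). For compound 4 the expected value is 36%, with an estimated range of 22% to 52%.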

Compound 4, percent growth inhibition at one concentration: 30%
Compound 4: middle estimate off by 6 percentage points, on the high side, and the stated range covers the measured number.
By their numbers in this assay, from the lowest: compounds 4, 2 and 1 (each within the scatter of the next); then compound 3.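

Placing the methoxy group as 2-methoxyphenyl rather than 3-methoxyphenyl on the double-bonded chain carbon gives a number 4 percentage points lower from compound 2 to compound 4 (within the scatter) in this assay, so this change of attachment, with the same atoms, leaves no readable trace on the number. The larger exchange of naphthalen-1-yl for 2-methoxyphenyl gives a number 10 percentage points lower from compound 1 to compound 4 (within the scatter) and stays inside the scatter as well, so naphthalen-1-yl, 3-methoxyphenyl and 2-methoxyphenyl cannot be told apart at this place, which now holds three aromatic groups and no step beyond the scatter. Nothing available on these compounds offers a reason for this flat result.

Open, on these data alone, is whether a group of another kind at this place, such as an aminophenyl ring or a carboxylic acid, would give a step beyond the scatter. Also open, as far as these compounds go, is whether 2-methoxyphenyl and 3-methoxyphenyl stay equivalent on the core of compound 3.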